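Series notes: tetrazole in place of methylpiperazine

The source may report more compounds than this note shows. Statements on the series, on what has been measured and on what is new or still open speak of the compounds shown alone.

Compound 1: `N#Cc1ccc(Nc2cc3[nH]c(-c4cccc(C(F)(F)F)c4)nc3cn2)nc1`
Compound 2: `CN1CCN(c2ccc(Nc3cc4[nH]c(-c5cccc(C(F)(F)F)c5)nc4cn3)nc2)CC1`
Compound 3: `FC(F)(F)c1cccc(-c2nc3cnc(Nc4ccc(-c5nnn[nH]5)cn4)cc3[nH]2)c1` (not yet measured)

In a physicochemical assay for solubility, using the shake flask method, in simulated intestinal fluid, measured as kinetic solubility, with a stated time of 20 h, at pH 6.5 (on this read-out lower numbers stand for lower solubility and higher numbers for higher solubility), compound 1 gives >= 50000 nM, which is a limit of the assay (the limit of >= 50000 nM in this assay, at which 1 of the 2 values shown sits). In this assay compound 2 gives < 5000 nM, also a limit (the limit of < 5000 nM in this assay, at which 1 of the 2 values shown sits). Compound 2 therefore stands at the lower of the two bounds seen so far and has no number of its own; the step of an at least 10-fold lower number from compound 1 to compound 2 (1.00 log units; beyond the scatter) is known only as a minimum. Compound 3 differs from compound 2 by 1H-tetrazol-5-yl in place of 4-methylpiperazin-1-yl on an aromatic carbon. Among the measured compounds shown here, the one measured step concerns the same position: an at least 10-fold lower number from compound 1 to compound 2 (1.00 log units; beyond the scatter) records what the 4-methylpiperazin-1-yl did on entering. For the measured compounds named here, its departure in favour of a group with no measured precedent leaves the direction open, so any expectation is weak. A rise in this assay is expected for compound 3, about an at least 4.0-fold higher number from compound 2 to compound 3 (0.60 log units; beyond the scatter), with wide uncertainty. For compound 3 the estimate in this assay is 20000 nM, range 3000 nM to 80000 nM.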

Compound 3, solubility: < 5000 nM
Compound 3 ended at the assay's limit; the forecaster's own chance of this, stated with the estimate: 40%; middle value at least 4.0-fold (0.60 log units) away from the limit.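

In this assay, 1H-tetrazol-5-yl in place of cyano gives an at least 10-fold lower number from compound 1 to compound 3 (1.00 log units; beyond the scatter), so the lower reading at this position is no longer tied to 4-methylpiperazin-1-yl alone: a five-membered aromatic ring with 4 hetero atoms now shares it with a six-membered non-aromatic ring. Compound 3 gives < 5000 nM, which is a limit of the assay. The step between compound 2 and compound 3 cannot be read, since both stand at the same limit: the limit of < 5000 nM in this assay, at which 2 of the 3 values shown sit.

On these data alone, how far compound 2 and compound 3 lie under that limit stays unknown, so the two groups cannot be ranked against each other. Also open, as far as these compounds go, is whether the high reading belongs to cyano specifically, which a carboxylic acid, a primary amide or a morpholine at this position would help to settle.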